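From an amide to a ureide on a branched chain

This account rests on a few compounds, and the source may have more. Where it says the series, first, only, none or still open, it means among the compounds named here.

Compound 1 `CCC[C@@H](C(N)=O)C(C)C` is a small branched-chain amide. Going by the values given here, in a functional assay on the whole organism (strain Sprague-Dawley) with Rattus norvegicus as the target (a higher number here means that more compound is needed for the effect, a lower number that less compound is needed), compound 1 gives 22 mg/kg, the lowest of the two numbers measured so far. Among the compounds with values here, its only neighbour is compound 2 `CCCC(C(N)=O)C(C)C`, which in this assay gives 27 mg/kg; the step of a 1.2-fold higher number from compound 1 to compound 2 (0.09 log units; within the scatter) lies within the scatter, and the sole difference between the two is the fact that one of compounds 1 and 2 is drawn with a defined configuration and the other without, at the place where they differ. Compound 3 `CCC[C@@H](C(=O)NC(N)=O)C(C)C` has not yet been measured. It differs from compound 1 by carbamoyl in place of hydrogen on an amide-type nitrogen. Within the data shown here, no measured step touches this amide-type nitrogen, so the pair of compound 1 and compound 2 says nothing about how this change will read out in this assay. Among the measured compounds shown here, with no measured step pointing in either direction, the expected step of a 1.1-fold lower number from compound 1 to compound 3 (0.04 log units; within the scatter) is kept small. Compound 3 is therefore estimated at 20 mg/kg in this assay, with a range from 8 mg/kg to 50 mg/kg.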

Compound 3, dose for half-maximal effect: 22 mg/kg
Beside the measured number, compound 3's estimate is 1.1-fold (0.04 log units) below it, within the range that was stated.
By their numbers in this assay, from the lowest: compounds 1, 3 and 2 (each within the scatter of the next).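

In this assay, going by these compounds alone, the first measured step at this amide-type nitrogen reads no change at the digits printed from compound 1 to compound 3 (within the scatter). Carbamoyl can therefore take the place of hydrogen here, turning the amino part of the amide into a ureido group, and the whole-organism dose stays within the scatter even though a group of several heavy atoms replaces a single hydrogen atom. The information at hand does not bear on why the amide and the ureide read alike.

This is a single change at a single position, so it sets no rule for the amide-type nitrogen in general. As far as these compounds go, whether a methyl or an acetyl group on that nitrogen, or a longer chain on the ureido end, would also stay within the scatter remains open.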